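A few compounds are considered here, and "the series" means these few. Any claim that something is new, unique, unknown or untested is made for them only; others in the source may bear on it.

Working notes on the series. Going by the values given here, in an ADME assay on HCT-116 cells (Homo sapiens) for cytotoxicity, read by MTT assay, with a stated time of 11 days (a higher number here means a weaker inhibitor of growth, a lower number a stronger inhibitor of growth), compound 3 `CCCCCCc1cc2c(=O)n(CCN=[N+]=[N-])cnc2s1` gives 14.7 ug/mL, the only numerical value so far among the three compounds measured. Compound 1 `CCCCCCCc1cc2c(=O)n(CC3CC3)cnc2s1` returns a limit of the assay in this assay, > 100 ug/mL. Compound 2 `CCCCCCCc1cc2c(=O)n(CCCBr)cnc2s1` likewise returns a limit of the assay, > 100 ug/mL. Among the compounds with values here, the one single-change step among the measured compounds, a step that the two limits leave unreadable from compound 1 to compound 2, is thus unreadable in size, and the limit of > 100 ug/mL in this assay, at which 2 of the 3 values shown sit, is the whole of what is known about it.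

Compound 4 `CCCCCCCc1cc2c(=O)n(CCN=[N+]=[N-])cnc2s1` is not yet measured. It differs from compound 3 by methyl in place of hydrogen on a saturated chain carbon, six bonds along the chain from an aromatic carbon. Within the data shown here, no measured step bears on this change: the only measured step concerns the group on the aromatic nitrogen and its size cannot be read. Nothing in the data therefore speaks for a step in either direction beyond the usual scatter, and the estimate for compound 4 rests on the value of compound 3 alone. The expected step is a 1.0-fold higher number from compound 3 to compound 4 (0.01 log units; within the scatter), that is, none beyond the scatter. Compound 4 is expected to give about 15 ug/mL in this assay, with a range from 6 ug/mL to 40 ug/mL.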

Compound 4, concentration for 50% growth inhibition: > 100 ug/mL
Compound 4: only a limit was reported; the forecaster's own chance of this, stated with the estimate: 25%; middle value at least 6.6-fold (0.82 log units) from the limit.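

In this assay, going by these compounds alone, methyl in place of hydrogen on a saturated chain carbon, six bonds along the chain from an aromatic carbon, gives an at least 6.8-fold higher number from compound 3 to compound 4 (0.83 log units; beyond the scatter), the first step whose size can be read at all, and its lower bound already lies beyond the scatter. Within the data shown here, with the group on the aromatic nitrogen held the same, this shows that a change of a single heavy atom at this chain position is enough to take a compound with a numerical value to a limit of the assay, something the earlier pair could not show, since its only step concerned the group on the aromatic nitrogen. The steps from compound 1 and compound 2 to compound 4 join at that same limit and cannot be read: the limit of > 100 ug/mL in this assay, at which 3 of the 4 values shown sit.

From the compounds shown here alone, how far the number rises from compound 3 to compound 4 stays open, as does whether ethyl or a longer chain at this position would behave as methyl does. Also open, going by these compounds, is whether the same step would appear with an amine or a carboxylic acid in place of the azido group.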